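Dropping the chloro group: from compound 2 to compound 3

This account rests on a few compounds, and the source may have more. Where it says the series, first, only, none or still open, it means among the compounds named here.

Compound 1 `COc1ccc(OC)c(/C=C/c2nnc(Nc3ccc(Cl)cc3)o2)c1`: > 100000 nM
Compound 2 `COc1ccc(OC)c(/C=C/C(=O)N/N=C/c2ccc(Cl)cc2)c1`: > 100000 nM

In a functional assay on SW-620 cells (Homo sapiens) for antiproliferative activity, read by sulforhodamine B assay, with a stated time of 48 h (a higher number here means a weaker inhibitor of growth, a lower number a stronger inhibitor of growth), compound 1 reaches only the assay limit of > 100000 nM. Compound 2 likewise gives only a limit, > 100000 nM, so no number for its growth inhibition is known. Both measured values thus stand at the limit of > 100000 nM in this assay, at which 2 of the 2 values shown sit, and compound 2 cannot be placed above or below any other compound on this evidence. Compound 3 `COc1ccc(OC)c(/C=C/C(=O)N/N=C/c2ccccc2)c1` differs from compound 2 by hydrogen in place of chloro on an aromatic carbon. Going by the values given here, no measured pair shows what this change does in this assay, so there is no step to lean on. Since compound 2 shows only a limit, the change is expected to give a step that the limit leaves unreadable from compound 2 to compound 3, none beyond the scatter. Compound 3 is therefore expected to give about 150000 nM, between 40000 nM and 600000 nM, most likely reported again only as a limit.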

Compound 3, concentration for total growth inhibition: 6230 nM
The estimate for compound 3 lay 24-fold (1.38 log units) above the measured number; measured number below the stated range.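

Going by these compounds alone, the first measured pair in this assay shows that this position matters: going from 4-chlorophenyl to phenyl, with hydrogen in place of chloro on an aromatic carbon para to a large group, gives an at least 16-fold lower number from compound 2 to compound 3 (1.20 log units; beyond the scatter). Within the data shown here, compound 3 is the first compound here with a real number, so removing this single chlorine is enough to bring the series into the measurable range of this assay. The full size of the step stays unknown, since the value for compound 2 is only a limit: the limit of > 100000 nM in this assay, at which 2 of the 3 values shown sit.

The compounds shown leave open whether chloro is uniquely unfavourable here, or whether a fluoro, a methoxy or an amine at the same place would also give a measurable number. They also leave open whether dropping the chloro from compound 1 would have a similar effect on the core of that compound.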